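Adding a methoxy group to the phenyl of compound 2

The compounds below may be only part of what the source reports. "The series", "measured", "known", "first", "only" and "open" are said of these compounds alone.

Measured so far in a functional assay on DU-145 cells (Homo sapiens) for inhibition, read by MTT assay, with a stated time of 72 h; a lower number here means a stronger inhibitor of growth, a higher number a weaker inhibitor of growth:
- compound 1, `N#C/C(=C\c1ccco1)C(=O)NCc1ccc(Cl)c(Cl)c1`: 24000 nM
- compound 2, `N#C/C(=C\c1ccccc1)C(=O)NCc1ccc(Cl)c(Cl)c1`: 71000 nM

Compound 2 has the highest of the two numbers shown; in this assay it gives 71000 nM, while compound 1 gives 24000 nM. Going by the values given here, the one measured step, a 3.0-fold higher number from compound 1 to compound 2 (0.47 log units; beyond the scatter), shows that swapping the ring at the end of the double-bonded chain changes the number modestly.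

Compound 3, `COc1ccc(/C=C(\C#N)C(=O)NCc2ccc(Cl)c(Cl)c2)cc1`, keeps the shared core of compound 2 and differs only in this: methoxy in place of hydrogen on an aromatic carbon. Among the compounds with values here, no measured step here touches a substituent on that phenyl ring; the only step known, from furan to phenyl, concerns a different change, so it offers no direct guide to the size or direction of this one. The expectation is therefore for a number close to that of compound 2, with a step of a 1.2-fold lower number from compound 2 to compound 3 (0.07 log units; within the scatter) that is not expected to go beyond the scatter. On that basis compound 3 is estimated to give 60000 nM in this assay, within a range from 20000 nM to 180000 nM.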

Compound 3, concentration for 50% growth inhibition: 70000 nM
The estimate for compound 3 lay 1.2-fold (0.07 log units) below the measured number, and the stated range covers the measured number.
By their numbers in this assay, from the lowest: compound 1; then compounds 3 and 2 (each within the scatter of the next).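

Placing a methoxy group on the phenyl ring, para to a large group, gives a 1.0-fold lower number from compound 2 to compound 3 (0.01 log units; within the scatter) in this assay, so at this one position the phenyl to 4-methoxyphenyl change produces no difference that can be told apart from the scatter. The ring still separates from the furan-2-yl of compound 1 with the added methoxy in place, at a 2.9-fold higher number from compound 1 to compound 3 (0.46 log units; beyond the scatter), a modest step that leaves compound 3 on the same side of compound 1 as compound 2. Nothing shown here explains why the methoxy group leaves the number within the scatter, and no measurement bears on a cause for this result.

This is a single group at a single position, so it does not show that this position is insensitive to every change: an amine, a carboxylic acid or a longer chain such as butoxy could still behave differently there. The compounds shown also leave open whether a methoxy group on another carbon of the phenyl ring, or on the furan-2-yl ring of compound 1, would give a number beyond the scatter.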